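Amino for Hydroxy on the Phenylethynyl Nucleoside

The compounds below may be only part of what the source reports. "The series", "measured", "known", "first", "only" and "open" are said of these compounds alone.

Going by the values given here, compound 2 `O=c1nc(O)c(C#Cc2ccccc2)cn1[C@@H]1O[C@H](CO)[C@@H](O)[C@H](O)[C@H]1O` gives 6200 nM in a functional assay on L1210 cells (Mus musculus) for cytotoxicity, with a stated time of 48 h (a higher number here means a weaker inhibitor, a lower number a stronger inhibitor), the only number available among the values shown. Compound 1 `CCCC#Cc1cn([C@@H]2O[C@H](CO)[C@@H](O)[C@H](O)[C@H]2O)c(=O)nc1N` returns merely a limit in this assay, >= 250000 nM. Compound 2 thus carries the sole measured figure to build on. Compound 3 `Nc1nc(=O)n([C@@H]2O[C@H](CO)[C@@H](O)[C@H](O)[C@H]2O)cc1C#Cc1ccccc1` is not yet measured. It differs from compound 2 by amino in place of hydroxy on an aromatic carbon. Among the compounds with values here, no measured step covers this change, so its size is open. A weakening step beyond the scatter is nevertheless expected, a 3.2-fold higher number from compound 2 to compound 3 (0.51 log units; beyond the scatter). Compound 3 is estimated at 20000 nM, between 3000 nM and 250000 nM.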

Compound 3, half-maximal inhibitory concentration: >= 250000 nM
Compound 3: a limit, no number; the forecaster's own chance of this, stated with the estimate: 35%; middle value at least 12-fold (1.09 log units) away from the limit.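

In this assay, going by these compounds alone, amino in place of hydroxy ortho to the 2-phenylethynyl group gives the first measured step at this position, an at least 40-fold higher number from compound 2 to compound 3 (1.60 log units; beyond the scatter), so the hydroxy matters strongly for the cytotoxicity seen here. Compound 3 stands as a limit and not a number, so this step gives only a minimum size: the limit of >= 250000 nM in this assay, at which 2 of the 3 values shown sit. The step between compound 1 and compound 3 cannot be read, since both values are limits. On these data alone, whether a methoxy or a methylamino group at this place would keep the activity stays open. So does how a propyl chain on the triple bond behaves alongside hydroxy.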